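A Stereocentre Inversion Tested for Cytotoxicity

This account rests on a few compounds, and the source may have more. Where it says the series, first, only, none or still open, it means among the compounds named here.

Compound 1 `CC1CCN(C[C@@H](O)[C@]23CC[C@H](CC2=O)C3(C)C)CC1` holds the highest of the two numbers recorded so far. In an ADME assay on HEK-293T cells (Homo sapiens) for cytotoxicity, read by MTT assay, with a stated time of 72 h (on this read-out higher numbers stand for weaker inhibition and lower numbers for stronger inhibition), compound 1 gives 169000 nM. Compound 2 `CC1(C)[C@@H]2CC[C@@]1([C@H](O)CN1CCN(c3ccccc3F)CC1)C(=O)C2` stands nearest, and in this assay compound 2 gives 120000 nM, a gap that lies within the scatter, so the two cannot be told apart. Compound 3 `CC1CCN(C[C@H](O)[C@]23CC[C@H](CC2=O)C3(C)C)CC1` is obtained from compound 1 by the two compounds have the same atoms and bonds and differ only in configuration as drawn: 1 of 3 stereo elements differ; a stereocentre at a saturated chain carbon is drawn S in compound 1 and R in compound 3. For the measured compounds named here, no pair of measured compounds shows what such a change does here. With nothing to point otherwise, the step from compound 1 to compound 3 is expected to be no change at the digits printed from compound 1 to compound 3 (within the scatter), nothing beyond the scatter. Compound 3 is therefore estimated at 169000 nM, with a range from 60000 nM to 450000 nM.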

Compound 3, half-maximal inhibitory concentration: 158000 nM
Estimate against measurement, compound 3: 1.1-fold (0.03 log units) above; the range from low to high includes it.
By their numbers in this assay, from the lowest: compounds 2, 3 and 1 (each within the scatter of the next).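

In this assay, the inversion gives a 1.1-fold lower number from compound 1 to compound 3 (0.03 log units; within the scatter), so the S and R configurations at this saturated chain carbon cannot be told apart on this read-out. This is the first direct comparison at this stereocentre, and what separates the pair is narrow: the fact that compounds 1 and 3 differ only in the configuration as drawn

The compounds shown leave open whether the inversion would remain as silent in a compound carrying a carboxylic acid or a longer chain on the amine. They also leave open whether changing the remaining stereo elements of the core would shift the number beyond the scatter.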